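Compound 3: 4-(trifluoromethyl)benzyl in place of hydrogen

The compounds below may be only part of what the source reports. "The series", "measured", "known", "first", "only" and "open" are said of these compounds alone.

In a functional assay on HCT-116 cells (Homo sapiens) for inhibition, read by MTT assay, with a stated time of 72 h (a lower number here means a stronger inhibitor of growth, a higher number a weaker inhibitor of growth), compound 2 (`O[C@H](COCCOC[C@@H](O)Cc1c[nH]nn1)Cc1ccc(-c2ccccc2)cc1`) gives > 100000 nM as a limit only, not a number. In this assay compound 1 (`O[C@H](COCCOC[C@@H](O)Cc1cn(Cc2ccc3ccccc3c2)nn1)Cc1ccc(-c2ccccc2)cc1`) gives 8600 nM as a measured number. The change to compound 3 (`O[C@H](COCCOC[C@@H](O)Cc1cn(Cc2ccc(C(F)(F)F)cc2)nn1)Cc1ccc(-c2ccccc2)cc1`) is 4-(trifluoromethyl)benzyl in place of hydrogen on an aromatic nitrogen. Among the compounds with values here, the one measured step at that nitrogen (an at least 11-fold higher number from compound 1 to compound 2 (1.06 log units; beyond the scatter)) puts hydrogen in place of (naphthalen-2-yl)methyl and is large and beyond the scatter. In this assay a large step to a lower number is therefore expected, with compound 1 (8600 nM) as the guide. The estimated change (an at least 10-fold lower number from compound 2 to compound 3 (1.00 log units; beyond the scatter)) is of that kind. Compound 3 is estimated at 10000 nM (expected range 4000 nM to 30000 nM).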

Compound 3, concentration for 50% growth inhibition: 2500 nM
Compound 3: the middle estimate sits 4.0-fold (0.60 log units) above what was measured; the whole stated range lies above it.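

In this assay compound 2 gives > 100000 nM, a limit and not a number. A second substituent on the aromatic nitrogen also brings a large step, an at least 40-fold lower number from compound 2 to compound 3 (1.60 log units; beyond the scatter), so the gain at this nitrogen is not tied to (naphthalen-2-yl)methyl alone. The aryl part of the substituent also matters, as 4-(trifluoromethyl)phenyl in place of naphthalen-2-yl gives a 3.4-fold lower number from compound 1 to compound 3 (0.54 log units; beyond the scatter).

Going by these compounds, whether a substituent on this nitrogen needs an aromatic ring at all stays open, as a plain butyl group would test. Also open, on these data alone, is whether an amine on the benzyl ring, or a longer chain carrying that ring, holds this level.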